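The compounds below may be only part of what the source reports. "The series", "measured", "known", "first", "only" and "open" are said of these compounds alone.

Of the compounds shown here, three built on one shared core have been tested in a functional assay on the whole organism (strain Wistar) for inhibition, with Rattus norvegicus as the target, read by paw edema, with stated times of 60 min and 1 h, at a dose of 100 mg/kg by the oral route; a lower number here means less inhibition, a higher number more inhibition at the dose given (going by the name of the read-out). Compound 1 `COc1cc2c(cc1OC)C(CC(=O)N(C)C)CC2` carries a dimethylamino group on the carbonyl carbon and in this assay gives 25%. Compound 2 `CCNC(=O)CC1CCc2cc(OC)c(OC)cc21` gives 15.6%, and compound 3 `COc1cc2c(cc1OC)C(CC(=O)NC(C)C)CC2` gives 31.3%. On these numbers compound 1 is the middle one of the three, yet both of its distances lie within the scatter: a number 9.4 percentage points lower from compound 1 to compound 2 (within the scatter) and a number 6.3 percentage points higher from compound 1 to compound 3 (within the scatter). Among the measured compounds shown here, the only step that reaches beyond the scatter is a number 15.7 percentage points higher from compound 2 to compound 3 (beyond the scatter).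

Compound 4 `CCCCNC(=O)CC1CCc2cc(OC)c(OC)cc21` has not yet been measured. It differs from compound 1 in one place: butylamino in place of dimethylamino on a carbonyl carbon. The two measured steps that bear on this are the exchanges of dimethylamino for ethylamino and for isopropylamino on the same carbonyl carbon, and both stayed within the scatter. A further exchange of the same kind, butylamino in place of dimethylamino, is therefore expected to give no step beyond the scatter in this assay, namely no change at the digits printed from compound 1 to compound 4 (within the scatter). Compound 4 is thus expected to give 25%, with a range from 13% to 38%.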

Compound 4, a percentage reported as inhibition, in the whole organism at one dose (the size of the read-out at that dose, not a potency): 31.3%
Compound 4: the middle estimate sits 6.3 percentage points below what was measured; measured number inside the range.
By their numbers in this assay, from the lowest: compounds 2, 1, 3 and 4 (each within the scatter of the next, the first and the last beyond it).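

On this carbonyl carbon, butylamino in place of dimethylamino gives a number 6.3 percentage points higher from compound 1 to compound 4 (within the scatter) in this assay, so a chain longer than any tested before, together with an amide hydrogen that dimethylamino lacks, leaves the read-out within the scatter of compound 1. The straight butyl and the branched isopropyl on the amide-type nitrogen read alike, with no change at the digits printed from compound 3 to compound 4 (within the scatter). Extending the ethyl chain gives a number 15.7 percentage points higher from compound 2 to compound 4 (beyond the scatter), a second step beyond the scatter, which sets compound 2 apart from compound 3 and compound 4, although compound 2 stays within the scatter of compound 1.

No measurement shown here accounts for any of these steps. From the compounds shown here alone, it remains open whether a longer chain such as hexylamino, or benzylamino, on this carbonyl carbon would give a step beyond the scatter from compound 4.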